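The compounds below may be only part of what the source reports. "The series", "measured", "known", "first", "only" and "open" are said of these compounds alone.

Of the compounds shown here, three built on one shared core have been tested in a functional assay on K562 cells (Homo sapiens) for antiproliferative activity, with a stated time of 72 h; a higher number here means a weaker inhibitor, a lower number a stronger inhibitor. Compound 1 `OC[C@H]1O[C@@H](n2cnc3c(NCc4ccccc4F)ncnc32)[C@H](O)[C@@H]1O` gives 33200 nM, compound 2 `OC[C@H]1O[C@@H](n2cnc3c(NCc4ccc(Cl)cc4)ncnc32)[C@H](O)[C@@H]1O` gives 218000 nM, and compound 3 `OC[C@H]1O[C@@H](n2cnc3c(NCc4ccc(Br)cc4)ncnc32)[C@H](O)[C@@H]1O` gives 68200 nM. Compound 3 therefore stands in the middle of the three numbers, weaker than compound 1 and stronger than compound 2.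

Compound 4 `OC[C@H]1O[C@@H](n2cnc3c(NCc4ccc(OC(F)(F)F)cc4)ncnc32)[C@H](O)[C@@H]1O` has trifluoromethoxy in place of bromo on an aromatic carbon, para to a large group: trifluoromethoxy in place of bromo on an aromatic carbon. Among the compounds with values here, the most direct evidence is the one measured swap of a single group on that aromatic carbon, bromo in place of chloro, which is a 3.2-fold lower number from compound 2 to compound 3 (0.50 log units; beyond the scatter). The replacements of 2-fluorophenyl are also modest: 4-chlorophenyl gives a 6.6-fold higher number from compound 1 to compound 2 (0.82 log units; beyond the scatter), and 4-bromophenyl gives a 2.1-fold higher number from compound 1 to compound 3 (0.31 log units; beyond the scatter). Within the data shown here, no tested compound carries trifluoromethoxy, so the data fix no direction, and a step no larger than these is the reasonable expectation. The expected step, close to no change, is a 1.2-fold higher number from compound 3 to compound 4 (0.07 log units; within the scatter). For compound 4 the estimated value is 80000 nM, with an expected range of 30000 nM to 220000 nM.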

Compound 4, half-maximal inhibitory concentration: > 166000 nM
Compound 4: no number, only a limit; the forecaster's own chance of this, stated with the estimate: 15%; middle value at least 2.0-fold (0.31 log units) away from the limit.
By their numbers in this assay, from the lowest: compound 1; then compound 3; then compound 2.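

In this assay the reading for compound 4 is a limit of the assay and not a number: the limit of > 166000 nM in this assay, at which 1 of the 4 values shown sits. Until now this aromatic carbon, para to a large group, had carried only chloro and bromo, and the limit still shows that trifluoromethoxy in place of bromo is a real loss, with an at least 2.4-fold higher number from compound 3 to compound 4 (0.38 log units; beyond the scatter). The step from compound 2 to compound 4 cannot be read, so the data do not tell whether trifluoromethoxy does better or worse than chloro here.

Methoxy, methyl or an amine on this same carbon would show whether any other group can match compound 3 at 68200 nM. From the compounds shown here alone, it also remains open whether fluoro here would come closer to compound 1, which carries its fluoro at a different place on the ring.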